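The compounds below may be only part of what the source reports. "The series", "measured", "known", "first", "only" and "open" are said of these compounds alone.

In an ADME assay on HEL cells (Homo sapiens) for cytotoxicity, with a stated time of 3 days (a lower number here means that less compound is tolerated, a higher number that more compound is tolerated), compound 3 `Cc1cc(-c2cccc(O)c2)cn2c(CSCCc3ccccc3)cnc12` gives 50 ug/mL. Compound 1 `Cc1cc(-c2cccs2)cn2c(CSCCc3ccccc3)cnc12` gives 32 ug/mL. Compound 2 `Cc1cc(-c2ccc(O)cc2)cn2c(CSCCc3ccccc3)cnc12` returns only a limit of the assay, > 50 ug/mL. Among the two plain numbers compound 3 stands highest, yet the step of a 1.6-fold higher number from compound 1 to compound 3 (0.19 log units; within the scatter) sits within the scatter, so the two cannot be ranked.

Compound 4 `Cc1cc(Br)cn2c(CSCCc3ccccc3)cnc12` differs from compound 3 in one place.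
bromo in place of 3-hydroxyphenyl on an aromatic carbon

Going by the values given here, two measured steps touch the same position. The step of an at least 1.5-fold higher number from compound 1 to compound 2 (0.19 log units; that floor lies within the scatter) and the step of a 1.6-fold higher number from compound 1 to compound 3 (0.19 log units; within the scatter) each swap one aromatic ring for another and stay within the scatter, while the step of a number no higher from compound 2 to compound 3 (the limit leaves the size open) cannot be sized since one side is a limit. Among the compounds with values here, none of these steps removes the ring altogether, so no measured step shows directly what bromo does here; the measured swaps only suggest that this position is not sensitive to change.

On that basis no step beyond the scatter is expected, so the step of a 1.3-fold lower number from compound 3 to compound 4 (0.10 log units; within the scatter) is an estimate of roughly no change. Compound 4 is therefore expected to give about 40 ug/mL, with a range from 18 ug/mL to 60 ug/mL. A plain number is not assured, since the limit of > 50 ug/mL in this assay, at which 1 of the 3 values shown sits, shows how close these values run to the ceiling of the assay.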

Compound 4, half-maximal cytotoxic concentration: 28 ug/mL
Beside the measured number, compound 4's estimate is 1.4-fold (0.15 log units) above it; measured number inside the range.
By their numbers in this assay, from the lowest: compounds 4, 1 and 3 (each within the scatter of the next).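

Going by these compounds alone, this is the first measured change at this position that removes the aromatic ring altogether: the bromo group leaves no ring and no hydrogen-bond donor where the 3-hydroxyphenyl group stood, yet in this assay the result stays within the scatter, with a 1.8-fold lower number from compound 3 to compound 4 (0.25 log units; within the scatter). The swap from the thiophen-2-yl group also stays within the scatter, with a 1.1-fold lower number from compound 1 to compound 4 (0.06 log units; within the scatter), so among these compounds an aromatic ring at this position is not needed to keep the number in the same range. The comparison with the 4-hydroxyphenyl group starts from a limit, not a number, and gives only a floor, an at least 1.7-fold lower number from compound 2 to compound 4 (0.25 log units; that floor lies within the scatter), so its true size cannot be read: the limit of > 50 ug/mL in this assay, at which 1 of the 4 values shown sits.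

Only aromatic rings and bromo are shown at this position, so what an amine, a carboxylic acid or a longer chain would do here remains open. The plain numbers in this assay all lie within the scatter of one another, so the compounds shown do not establish an order among these groups.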